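Methoxy placement across two rings of a chalcone series

The source may report more compounds than this note shows. Statements on the series, on what has been measured and on what is new or still open speak of the compounds shown alone.

Working notes on four compounds. Compound 1 `COc1cc(/C=C/C(=O)c2ccccc2F)cc(OC)c1OC` in a functional assay on A549 cells (Homo sapiens) for cytotoxicity, read by MTT assay, with a stated time of 72 h (on this read-out lower numbers stand for stronger inhibition and higher numbers for weaker inhibition), gives > 100000 nM, a limit of the assay rather than a number. Compound 2 `COc1ccc(C(=O)/C=C/c2cc(OC)c(OC)c(OC)c2)c(F)c1` gives 108 nM in this assay. The step of an at least 920-fold lower number from compound 1 to compound 2 (2.96 log units; beyond the scatter) follows from methoxy in place of hydrogen on an aromatic carbon, and compound 1 sits at the limit of > 100000 nM in this assay, at which 2 of the 3 values shown sit.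

Compound 3 `COc1ccc(C(=O)/C=C/c2ccc(OC)cc2OC)c(F)c1` has the same atoms as compound 1 joined differently; the difference between the two cores is not broken down here. In this assay compound 3 gives > 100000 nM, again a limit of the assay.

Compound 4 `COc1ccc(C(=O)/C=C/c2c(OC)cc(OC)cc2OC)c(F)c1` is not yet measured in this assay. From compound 3 it differs by methoxy in place of hydrogen on an aromatic carbon. This is the same kind of change as from compound 1 to compound 2, not the same change: there the entering methoxy sat meta to a fluoro group and para to a large group, here it sits ortho to a large group and meta to two methoxy groups. Given that compound 3 shows only a limit, > 100000 nM, and that the place is not the same, the expected step of an at least 1.6-fold lower number from compound 3 to compound 4 (0.22 log units; that floor lies within the scatter) is set much smaller than an at least 920-fold lower number from compound 1 to compound 2 (2.96 log units; beyond the scatter). For compound 4 the expected value in this assay is 60000 nM, between 8000 nM and 300000 nM.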

Compound 4, half-maximal inhibitory concentration: > 100000 nM
Compound 4 ended at the assay's limit; the forecaster's own chance of this, stated with the estimate: 50%; middle value at least 1.6-fold (0.22 log units) from the limit.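

Compound 3 and compound 4 both sit at a limit of the assay rather than at a number, so the step between them cannot be read: the limit of > 100000 nM in this assay, at which 3 of the 4 values shown sit.

The compounds shown leave open whether methoxy in place of hydrogen, at this place on the ring, changes the read-out at all.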